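A few compounds are considered here, and "the series" means these few. Any claim that something is new, unique, unknown or untested is made for them only; others in the source may bear on it.

Measured compounds:
compound 1, `COc1cc(N)c(Cl)cc1C(=O)NC1CCN(CC2CCN(C(=O)CCCN)CC2)CC1`, gives 3.99 nM in an assay on striatum for inhibition of 5-hydroxytryptamine receptor 4 (Cavia porcellus), read by radioligand binding; a lower number here means a stronger inhibitor, a higher number a weaker inhibitor
compound 2, `COc1cc(N)c(Cl)cc1C(=O)NC1CCN(CC2CCN(CCCCN)CC2)CC1`, gives 6.47 nM in this assay
compound 3, `COc1cc(N)c(Cl)cc1C(=O)NC1CCN(CC2CCN(C(=O)CN)CC2)CC1`, gives 9.3 nM in this assay

Compound 1 has the lowest number of the three in this assay. Compound 4, `COc1cc(N)c(Cl)cc1C(=O)NC1CCN(CC2CCN(C(=O)CCCCN)CC2)CC1`, differs from compound 1 by aminomethyl in place of amino on a saturated chain carbon, three bonds along the chain from a carbonyl carbon. Going by the values given here, two measured steps bear on the chain at this place: shortening it gave a 2.3-fold higher number from compound 1 to compound 3 (0.37 log units; beyond the scatter), while exchanging the chain and its carbonyl for the 4-aminobutyl group gave a 1.6-fold higher number from compound 1 to compound 2 (0.21 log units; within the scatter). Lengthening by one carbon thus seems unlikely to move the number beyond the scatter, so the step in this assay from compound 1 to compound 4 is expected to be small, a 1.1-fold higher number from compound 1 to compound 4 (0.05 log units; within the scatter). Compound 4 is therefore estimated at 4.5 nM, in the range 2 nM to 10 nM.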

Compound 4, half-maximal inhibitory concentration: 3.91 nM
For compound 4 the middle estimate is 1.2-fold (0.06 log units) above the measured one, and the stated range covers the measured number.
By their numbers in this assay, from the lowest: compounds 4, 1, 2 and 3 (each within the scatter of the next, the first and the last beyond it).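

In this assay, adding one carbon to the chain has no effect beyond the scatter (a 1.0-fold lower number from compound 1 to compound 4 (0.01 log units; within the scatter)), so this position accepts the 4-aminobutyl chain on the carbonyl as well as the shorter chain of compound 1. The chain on the carbonyl in compound 4 retains the advantage seen over the shortest chain (a 2.4-fold lower number from compound 3 to compound 4 (0.38 log units; beyond the scatter)), while the comparison with the carbonyl-free chain remains within the scatter (a 1.7-fold lower number from compound 2 to compound 4 (0.22 log units; within the scatter)). Nothing available explains these numbers. The compounds shown leave open whether a still longer chain would hold the number, and whether a carboxylic acid or a hydroxyl group could replace the terminal amine.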